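Replacing the indole of compound 3 with a lactam bicycle

This account rests on a few compounds, and the source may have more. Where it says the series, first, only, none or still open, it means among the compounds named here.

Compound 1 `Cn1c(=O)c(S(=O)(=O)c2ccc(F)cc2F)cc2cnc(Nc3ccc4[nH]ncc4c3)nc21`: 30000 nM
Compound 2 `Cn1c(=O)c(S(=O)(=O)c2ccc(F)cc2F)cc2cnc(Nc3ccc4cccc(O)c4n3)nc21`: 5000 nM
Compound 3 `Cc1cc2cc(Nc3ncc4cc(S(=O)(=O)c5ccc(F)cc5F)c(=O)n(C)c4n3)ccc2[nH]1`: 750 nM

In a functional assay on DU-145 cells (Homo sapiens) for inhibition, read by trypan blue exclusion, with a stated time of 72 h (on this read-out higher numbers stand for weaker inhibition and lower numbers for stronger inhibition), compound 3 gives the lowest number of the three, with a 6.7-fold lower number from compound 2 to compound 3 (0.82 log units; beyond the scatter) and a 40-fold lower number from compound 1 to compound 3 (1.60 log units; beyond the scatter), both beyond the scatter, so it is the strongest inhibitor of the set. Compound 4 `Cn1c(=O)c(S(=O)(=O)c2ccc(F)cc2F)cc2cnc(Nc3ccc4c(c3)CC(=O)N4)nc21` differs from compound 3 by a group of 10 heavy atoms (8 carbon, 1 nitrogen, 1 oxygen; one five-membered non-aromatic ring with 1 hetero atom, one six-membered aromatic ring of carbon only) in place of a group of 10 heavy atoms (9 carbon, 1 nitrogen; one five-membered aromatic ring with 1 hetero atom, one six-membered aromatic ring of carbon only), on a nitrogen on an aromatic ring. Going by the values given here, the steps that bear on this are a 40-fold lower number from compound 1 to compound 3 (1.60 log units; beyond the scatter) and a 6.7-fold lower number from compound 2 to compound 3 (0.82 log units; beyond the scatter), which show that swapping the group on this nitrogen moves the number widely, and a 6.0-fold lower number from compound 1 to compound 2 (0.78 log units; beyond the scatter). Among the compounds with values here, no measured step involves a non-aromatic five-membered ring, so the direction is uncertain; compound 4 is expected to lose against compound 3, with a 6.7-fold higher number from compound 3 to compound 4 (0.82 log units; beyond the scatter) estimated. Compound 4 is estimated at 5000 nM, in a range from 1000 nM to 25000 nM.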

Compound 4, half-maximal inhibitory concentration: 100000 nM
For compound 4 the middle estimate is 20-fold (1.30 log units) below the measured one; measured number outside the range, above it.
By their numbers in this assay, from the lowest: compound 3; then compound 2; then compound 1; then compound 4.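

In this assay, compound 4 gives the highest number of the four, so the group with the five-membered non-aromatic ring is the weakest on this nitrogen among those shown: a 130-fold higher number from compound 3 to compound 4 (2.12 log units; beyond the scatter) is the largest step seen at this position, a 20-fold higher number from compound 2 to compound 4 (1.30 log units; beyond the scatter) is also large, and a 3.3-fold higher number from compound 1 to compound 4 (0.52 log units; beyond the scatter) is modest but beyond the scatter. Even the 1H-indazol-5-yl group of compound 1 thus does better than the new group. No evidence is available to explain this loss. As far as these compounds go, whether an amine or a carboxylic acid on the 2-methyl-1H-indol-5-yl group of compound 3 would lower the number further remains open.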